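Swapping the Aryl Group on the Ring Nitrogen

The source may report more compounds than this note shows. Statements on the series, on what has been measured and on what is new or still open speak of the compounds shown alone.

Compound 1 `O=C(NCCCCc1ccccc1)c1cccc(C2SCC(=O)N2c2cccc(F)c2)c1`: 92%
Compound 2 `COc1cccc(OC)c1N1C(=O)CSC1c1cccc(C(=O)NCCCCc2ccccc2)c1`: 80%
Compound 3 `CC(F)(F)c1cccc(N2C(=O)CSC2c2cccc(C(=O)NCCCCc3ccccc3)c2)c1`: 92%

In a functional assay on MG-63 cells (Homo sapiens) for inhibition, read by CCK-8 assay, with a stated time of 72 h, tested at 1 uM (on this read-out higher numbers stand for more inhibition at the one concentration tested (going by the name of the read-out) and lower numbers for less inhibition), compound 3 gives 92%, level with compound 1 at the digits shown, and together these are the highest of the three numbers; compound 2 stands apart, as the step of a number 12 percentage points higher from compound 2 to compound 3 (beyond the scatter) shows. Compound 4 `COc1ccc(N2C(=O)CSC2c2cccc(C(=O)NCCCCc3ccccc3)c2)c(OC)c1` differs from compound 3 in one place: a group of 10 heavy atoms (8 carbon, 2 oxygen; one six-membered aromatic ring of carbon only) in place of a group of 10 heavy atoms (8 carbon, 2 fluorine; one six-membered aromatic ring of carbon only), on an amide-type nitrogen in a ring. Within the data shown here, two measured steps bear on this change. Among the measured compounds shown here, the step of a number 12 percentage points higher from compound 2 to compound 3 (beyond the scatter) and the step of a number 12 percentage points lower from compound 1 to compound 2 (beyond the scatter) both show a dimethoxyphenyl on that ring nitrogen running lower than a fluorinated phenyl, though the dimethoxy pattern of compound 4 is not the one in compound 2. A step of a number 10 percentage points lower from compound 3 to compound 4 (within the scatter) is therefore expected. Compound 4 is estimated at 82%, with a range from 70% to 92%.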

Compound 4, a percentage reported as inhibition, at one concentration (the size of the read-out at that concentration, not a potency): 56%
For compound 4 the middle estimate is 26 percentage points above the measured one; measured number outside the range, below it.
By their numbers in this assay, from the lowest: compound 4; then compound 2; then compounds 1 and 3 (each within the scatter of the next).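

In this assay the placing of the methoxy groups on the ring nitrogen's phenyl counts, not only their presence: exchanging the 2,6-dimethoxyphenyl for the 2,4-dimethoxyphenyl gives a number 24 percentage points lower from compound 2 to compound 4 (beyond the scatter) on an otherwise unchanged molecule. Set against the fluorinated phenyl groups, the same 2,4-dimethoxyphenyl gives a number 36 percentage points lower from compound 3 to compound 4 (beyond the scatter) and a number 36 percentage points lower from compound 1 to compound 4 (beyond the scatter) and both of these steps are large. Nothing available here explains why these two dimethoxy patterns part so widely. Going by these compounds, whether a single methoxy group, a hydroxyl or a dimethylamino group on that phenyl would hold the number high remains open.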